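Open-Chain Amine Analogues Read in a Cellular Activation Assay

The compounds below may be only part of what the source reports. "The series", "measured", "known", "first", "only" and "open" are said of these compounds alone.

Measured compounds:
compound 1, `COc1cc(/C=C/C(=O)/C=C(/C=C/c2ccc(O)c(OC)c2)NCCO)ccc1O`: 90.9%
compound 2, `COc1cc(/C=C/C2=CC(=O)CC(c3ccc(O)c(OC)c3)N2CCCO)ccc1O`: 80.3%
compound 3, `COCCCN1C(/C=C/c2ccc(O)cc2)=CC(=O)CC1c1ccc(O)cc1`: 91.7%

Three compounds have been run in an ADME assay on CHO-K1 cells (Cricetulus griseus) for activation, read by fluorescence, tested at 10 uM; on this read-out higher numbers stand for a weaker effect at the one concentration tested and lower numbers for a stronger effect. Compound 1 gives 90.9% in this assay, the second highest of the three numbers. Compound 3, with 91.7%, lies within the scatter of compound 1, so the two cannot be told apart. Within the data shown here, compound 2, with 80.3%, sits beyond the scatter on the lower side, and is the one measured compound that separates from compound 1.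

The next compound, compound 4, is `COCCCNC(=C\C(=O)/C=C/c1ccc(O)c(OC)c1)/C=C/c1ccc(O)c(OC)c1`. It differs from compound 1 in one place: methoxymethyl in place of hydroxy on a saturated chain carbon, two bonds along the chain from an amine nitrogen. The same shared core and the same two aryl ends are kept; only the chain on the amine nitrogen changes.

Among the measured compounds shown here, no measured pair differs in just this way, so no step can be drawn from the data. Compound 3, which carries the 3-methoxypropyl chain on its nitrogen, reads within the scatter of compound 1, and that is the nearest hint on record. The step from compound 1 to compound 4 is therefore expected to be small, a number 2.9 percentage points lower from compound 1 to compound 4 (within the scatter), and not beyond the scatter.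

Compound 4 is expected to give 88% in this assay, within a range from 76% to 98%.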

Compound 4, a percentage reported as activity, at one concentration (the size of the read-out at that concentration, not a potency): 81.2%
Estimate against measurement, compound 4: 6.8 percentage points above, and the stated range covers the measured number.
By their numbers in this assay, from the lowest: compounds 2, 4, 1 and 3 (each within the scatter of the next, the first and the last beyond it).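

In this assay, among these compounds, the change on the amine nitrogen reads as a number 9.7 percentage points lower from compound 1 to compound 4 (within the scatter), and this is the first direct reading of methoxymethyl in place of hydroxy at this place on the chain. The open-chain compound therefore keeps a reading that cannot be told apart from its parent, even though the swap gives up the hydrogen-bond donor of the hydroxy and adds two carbons to the chain, so this position accepts the 3-methoxypropyl chain in place of the 2-hydroxyethyl chain without a step beyond the scatter. Nothing on record gives a reason for this reading, and a single step of this size supports no trend.

The change lengthens the chain and caps its oxygen at once, so the compounds shown leave open which of the two matters, and a 3-hydroxypropyl or a 2-methoxyethyl chain on the same nitrogen would separate them. They also leave open how this position would read with a primary amine or a carboxylic acid at the end of the chain.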